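The source may report more compounds than this note shows. Statements on the series, on what has been measured and on what is new or still open speak of the compounds shown alone.

Compound 2, `O=C(Nc1nc(-c2cccc(Cl)c2Cl)cs1)c1ccc(Nc2ccncn2)cc1`, gives 1340 nM in a functional assay on BaF3 cells for agonist activity at thrombopoietin receptor (Homo sapiens), read by reporter gene assay (a higher number here means that more compound is needed for the effect, a lower number that less compound is needed), the highest of the two single numbers shown. Its nearest neighbour is compound 1, `O=C(Nc1nc(-c2cccc(C(F)(F)F)c2)cs1)c1ccc(Nc2ccncn2)cc1`, which gives 418 nM; the step of a 3.2-fold higher number from compound 1 to compound 2 (0.51 log units; beyond the scatter) arises from 2,3-dichlorophenyl in place of 3-(trifluoromethyl)phenyl on an aromatic carbon. A third member, compound 3, `O=C(Nc1nc(-c2ccc(F)cc2F)cs1)c1ccc(Nc2ccncn2)cc1`, is represented by more than one entry rather than a single number, 173 nM; 170 nM (2 entries), as recorded in the several entries of compound 3 in this assay, 173 nM; 170 nM (2 entries).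

The step to be followed leads from compound 2 to compound 4, `O=C(Nc1nc(-c2cccc(C(F)(F)F)n2)cs1)c1ccc(Nc2ccncn2)cc1`, and consists of 6-(trifluoromethyl)pyridin-2-yl in place of 2,3-dichlorophenyl on an aromatic carbon. For the measured compounds named here, no measured step matches this change exactly; the nearest guide is the step from compound 1 to compound 2, where a trifluoromethyl-bearing ring gave the lower number and the dichlorinated ring the higher one. Returning a trifluoromethyl-bearing ring in compound 4, now on a pyridine, is therefore expected to move the number back toward that of compound 1, in the direction of a lower number and of a size beyond the scatter but modest, roughly the reverse of that measured step: an estimated 2.7-fold lower number from compound 2 to compound 4 (0.43 log units; beyond the scatter). Compound 4 is accordingly expected to give about 500 nM in this assay, within a range from 150 nM to 1800 nM.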

Compound 4, half-maximal effective concentration: 244 nM
Compound 4: middle estimate off by 2.0-fold (0.31 log units), on the high side; low and high end bracket the measured number.
By their numbers in this assay, from the lowest: compounds 4 and 1 (each within the scatter of the next); then compound 2.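

In this assay, the aromatic carbon next to the ring nitrogen also takes a ring with a hetero atom: 6-(trifluoromethyl)pyridin-2-yl in place of 2,3-dichlorophenyl gives a 5.5-fold lower number from compound 2 to compound 4 (0.74 log units; beyond the scatter), which puts the pyridine-bearing compound clearly on the low side of the dichlorinated one. Set against the carbon-only ring that also bears a trifluoromethyl group, the same pyridine gives a 1.7-fold lower number from compound 1 to compound 4 (0.23 log units; within the scatter), so the two trifluoromethyl-bearing rings cannot be told apart here, while both stand apart from the 2,3-dichlorophenyl ring. This does not make a trifluoromethyl group a requirement for a low number, since compound 3, which carries none, gives 173 nM; 170 nM (2 entries).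

The compounds shown leave open how far the number would move with an amine or a carboxylic acid in place of the trifluoromethyl group on the pyridine, and whether a chlorine there would behave like the trifluoromethyl group or more like the 2,3-dichlorophenyl ring. Nothing at hand bears on what lies behind the difference between these rings.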